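A few compounds are considered here, and "the series" means these few. Any claim that something is new, unique, unknown or untested is made for them only; others in the source may bear on it.

Measured so far in a physicochemical assay for solubility, in phosphate buffer, at pH 6.5; a higher number here means a more soluble compound, a lower number a less soluble compound:
- Compound 1 `CNc1nc(NCCN2CCNCC2)c2sc(-c3ccc(C(F)(F)F)cc3)cc2n1`: 115 ug/mL
- Compound 2 `CNc1nc(N2CCC(N)CC2)c2sc(-c3ccc(C(F)(F)F)cc3)cc2n1`: 17 ug/mL

Of these two compounds, compound 2 has the lower number in this assay, and the gap to compound 1 lies beyond the scatter. Going by the values given here, the only measured step is a 6.8-fold lower number from compound 1 to compound 2 (0.83 log units; beyond the scatter). It replaces (2-(piperazin-1-yl)ethyl)amino with 4-aminopiperidin-1-yl on an aromatic carbon, so it shows how far the numbers can move with a change elsewhere in the molecule, but it gives no direct reading on the next change.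

Compound 3 `Nc1nc(N2CCC(N)CC2)c2sc(-c3ccc(C(F)(F)F)cc3)cc2n1` differs from compound 2 by hydrogen in place of methyl on a nitrogen on an aromatic ring, or methylamino to amino. Among the compounds with values here, no measured step involves this change, so no step beyond the scatter is expected in this assay, and no direction is firmly favoured. The expectation therefore starts from compound 2 at 17 ug/mL.

The expected change is a 1.2-fold higher number from compound 2 to compound 3 (0.07 log units; within the scatter). For compound 3, the estimated value is 20 ug/mL, with an expected range of 7 ug/mL to 55 ug/mL.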

Compound 3, solubility: 134 ug/mL
The estimate for compound 3 lay 6.7-fold (0.83 log units) below the measured number; measured number outside the range, above it.
By their numbers in this assay, from the lowest: compound 2; then compounds 1 and 3 (each within the scatter of the next).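

In this assay, hydrogen in place of methyl on a nitrogen on an aromatic ring gives a 7.9-fold higher number from compound 2 to compound 3 (0.90 log units; beyond the scatter) with the 4-aminopiperidin-1-yl group held constant. The earlier step had shown movement only at the other substituent, so this is the first reading at this position, and it shows that the number responds here too, with a step beyond the scatter. By the computed count, the change removes only a single heavy atom, one carbon, with no ring and no net charge involved, yet that is enough to move the number clearly; nothing available bears on the reason for this rise.

As far as these compounds go, this reading rests on one matched pair, so it remains open whether methylamino to amino would act in the same direction and to a similar extent with the (2-(piperazin-1-yl)ethyl)amino group in place of the 4-aminopiperidin-1-yl group. The compounds shown also leave open how the number would respond to a longer chain such as ethyl, or to an acetyl group, on that same nitrogen.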